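The compounds below may be only part of what the source reports. "The series", "measured", "known", "first", "only" and "open" are said of these compounds alone.

Measured compounds in a functional assay on A2780 cells (Homo sapiens) for antiproliferative activity, read by MTT assay, with a stated time of 3 days; a higher number here means a weaker inhibitor, a lower number a stronger inhibitor:
- compound 1 `COC1(c2ccc(Br)cc2)SC=C(C)n2c1noc2=O`: 148000 nM
- compound 2 `CC/C=C/COC1(c2ccc(Br)cc2)SC=C(C)n2c1noc2=O`: 59000 nM

Compound 1 has the highest number of the two, the step of a 2.5-fold lower number from compound 1 to compound 2 (0.40 log units; beyond the scatter) setting it apart from compound 2. Compound 3 `COC1(c2ccc(Cl)cc2)SC=C(C)n2c1noc2=O` has not yet been measured. It differs from compound 1 by chloro in place of bromo on an aromatic carbon. The one measured step changes the chain on the oxygen, not the halogen, so nothing shown bears on this change, and no shift beyond the scatter is expected in this assay. The expected step from compound 1 to compound 3 is therefore no change at the digits printed from compound 1 to compound 3 (within the scatter). Compound 3 is estimated at 148000 nM, within 70000 nM to 310000 nM.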

Compound 3, half-maximal inhibitory concentration: 166000 nM
The estimate for compound 3 lay 1.1-fold (0.05 log units) below the measured number, within the range that was stated.
By their numbers in this assay, from the lowest: compound 2; then compounds 1 and 3 (each within the scatter of the next).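

In this assay chloro in place of bromo on the aromatic carbon gives a 1.1-fold higher number from compound 1 to compound 3 (0.05 log units; within the scatter) and so leaves the reading within the scatter. Going by these compounds alone, this is the first information on the halogen at this position, since the earlier step changed only the chain on the oxygen, and the two halogens are interchangeable here in this assay. No available data explain this result.

Open, going by these compounds, is whether other groups at this aromatic carbon, such as an amine or a carboxylic acid, would move the number. Also open, on these data alone, is whether the longer chain on the oxygen acts the same way with chloro in place of bromo.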